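From butylamino to ethyl(methyl)amino on a sulfonyl sulfur

The compounds below may be only part of what the source reports. "The series", "measured", "known", "first", "only" and "open" are said of these compounds alone.

- compound 1 `COC(=O)NC(=O)c1ccsc1NC(=O)c1ccc(S(=O)(=O)N2CCC(OC)CC2)cc1` gives 18 ug/mL 
- compound 2 `CCCCNS(=O)(=O)c1ccc(C(=O)Nc2sccc2C(=O)NC(=O)OC)cc1` gives 29.5 ug/mL 

Both numbers come from a toxicity assay on Vero cells (Chlorocebus sabaeus) for cytotoxicity, read by MTT assay (a lower number here means a stronger inhibitor, a higher number a weaker inhibitor), and lie within the usual scatter of each other, so compound 2 stands level with compound 1. The next compound, compound 3 `CCN(C)S(=O)(=O)c1ccc(C(=O)Nc2sccc2C(=O)NC(=O)OC)cc1`, has not yet been measured. It carries ethyl(methyl)amino in place of butylamino on a sulfonyl sulfur. For the measured compounds named here, only one measured step bears on this change, and it also alters the group on that sulfur. That step, a 1.6-fold higher number from compound 1 to compound 2 (0.21 log units; within the scatter), stayed within the scatter, so no change beyond the scatter is expected in this assay, although a single step is thin evidence. The estimated step is a 1.2-fold lower number from compound 2 to compound 3 (0.09 log units; within the scatter), and it remains only an expectation. In this assay compound 3 is expected at 24 ug/mL, with an estimated range of 11 ug/mL to 50 ug/mL until the measurement is known.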

Compound 3, half-maximal inhibitory concentration: 10.4 ug/mL
Beside the measured number, compound 3's estimate is 2.3-fold (0.36 log units) above it; the measured number lies below the stated range.
By their numbers in this assay, from the lowest: compounds 3, 1 and 2 (each within the scatter of the next, the first and the last beyond it).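

In this assay, the group on the sulfonyl sulfur now produces a step beyond the scatter: replacing butylamino with ethyl(methyl)amino gives a 2.8-fold lower number from compound 2 to compound 3 (0.45 log units; beyond the scatter) and marks this position as one where the number can respond to a change. The response is modest and depends on the pair compared, as replacing 4-methoxypiperidin-1-yl with ethyl(methyl)amino gives a 1.7-fold lower number from compound 1 to compound 3 (0.24 log units; within the scatter) and leaves those two compounds level. No measurement shown accounts for the difference between compound 2 and compound 3.

This swap removes the hydrogen-bond donor and one heavy atom together, so the compounds shown cannot separate those two differences. As far as these compounds go, how the number would run with ethylamino on the same sulfur, which keeps a hydrogen on the nitrogen, or with a longer chain such as hexylamino, stays open.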